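The source may hold more compounds than are shown below. What is called first, only, known or untested is meant among the compounds shown, and "the series" means these compounds.

Compound 1 `O=C(Nc1cc(Cl)nc(Cl)c1)Nc1cc2ccccn2n1`: 5130 nM
Compound 2 `O=C(Nc1cc(Cl)nc(Cl)c1)Nc1cc2ccc(Br)cn2n1`: 5260 nM

Within the data shown here, in a functional assay on HCT-116 cells (Homo sapiens) for inhibition, read by MTT assay, with a stated time of 72 h, in the presence of a further agent that is not named here (on this read-out lower numbers stand for an effect already at smaller amounts and higher numbers for an effect only at larger amounts of compound), compound 2 gives 5260 nM and lies within the scatter of compound 1, its only neighbour on these numbers, so the two cannot be told apart. Compound 3 `O=C(Nc1cc(Cl)nc(Cl)c1)Nc1cc2ccc(-c3ccccc3)cn2n1` is still unmeasured. It carries phenyl in place of bromo on an aromatic carbon of compound 2, counted as phenyl in place of bromo on an aromatic carbon in full.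

Among the measured compounds shown here, only one measured step bears on this change: a 1.0-fold higher number from compound 1 to compound 2 (0.01 log units; within the scatter) for bromo in place of hydrogen on that same carbon. For the measured compounds named here, it stays within the scatter, yet no measured compound carries a ring at this carbon, so the evidence for phenyl is thin. The expected step is a 1.2-fold lower number from compound 2 to compound 3 (0.07 log units; within the scatter) in this assay with no firm direction and nothing foreseen beyond the scatter. Compound 3 is estimated at 4500 nM with a range from 1500 nM to 13000 nM expected.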

Compound 3, half-maximal effective concentration: 5130 nM
Compound 3: middle estimate off by 1.1-fold (0.06 log units), on the low side, within the range that was stated.
By their numbers in this assay, from the lowest: compounds 1, 3 and 2 (each within the scatter of the next).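

In this assay, phenyl in place of bromo gives a 1.0-fold lower number from compound 2 to compound 3 (0.01 log units; within the scatter), and phenyl in place of hydrogen gives no change at the digits printed from compound 1 to compound 3 (within the scatter). Until now this aromatic carbon, two atoms from the ring nitrogen, had carried only hydrogen or bromo; these steps show that a six-membered aromatic ring there also stays within the scatter, so hydrogen, bromo and phenyl cannot be told apart at this position. No measurement offers an explanation for this flat result.

From the compounds shown here alone, whether an amine, a carboxylic acid or a longer chain on this carbon would give a number beyond the scatter remains open. The compounds shown also leave open whether any change elsewhere on the shared core would do so.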